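The compounds below may be only part of what the source reports. "The series", "measured", "known", "first", "only" and "open" are said of these compounds alone.

- Compound 1 (`CC(O)(CSc1ccc(C(F)(F)F)cc1)C(=O)Nc1ccc(S(F)(F)(F)(F)F)cc1`) gives 28800 nM in a functional assay on DU-145 cells (Homo sapiens) for antiproliferative activity, read by propidium iodide staining, with a stated time of 96 h; on this read-out lower numbers stand for stronger inhibition and higher numbers for weaker inhibition
- Compound 2 (`CC(O)(CSc1ccc(C(F)(F)F)cc1)C(=O)Nc1cccc(S(F)(F)(F)(F)F)c1`) gives 27200 nM
- Compound 3 (`CC(O)(COc1ccc(S(F)(F)(F)(F)F)cc1)C(=O)Nc1ccc(C#N)c(C(F)(F)F)c1`) gives 25500 nM

Compound 3 stands within the scatter of both compound 1 and compound 2, so the three values do not separate. Compound 4 (`CC(O)(COc1ccc(S(F)(F)(F)(F)F)cc1)C(=O)Nc1ccc([N+](=O)[O-])c(C(F)(F)F)c1`) keeps the core of compound 3 but carries nitro in place of cyano on an aromatic carbon. Going by the values given here, no measured pair shows this change or any other single change, so the data offer no direct guide to its size. In this assay no shift beyond the scatter is expected, and the estimated step of a 1.1-fold lower number from compound 3 to compound 4 (0.03 log units; within the scatter) has no firm direction. For compound 4 the estimated value is 24000 nM with an expected range from 11000 nM to 50000 nM in this read-out.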

Compound 4, half-maximal inhibitory concentration: 21200 nM
Compound 4: middle estimate off by 1.1-fold (0.05 log units), on the high side; low and high end bracket the measured number.
By their numbers in this assay, from the lowest: compounds 4, 3, 2 and 1 (each within the scatter of the next).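

In this assay, going by these compounds alone, this is the first pair that differs in one place, and nitro in place of cyano on this aromatic carbon, ortho to a trifluoromethyl group, gives a 1.2-fold lower number from compound 3 to compound 4 (0.08 log units; within the scatter). At this position, with this core, the two groups therefore do not separate. No available evidence bears on this result. The compounds shown leave open whether an amine or a carboxylic acid on the same carbon would shift the number beyond the scatter. They also leave open whether the exchange of cyano for nitro would behave alike on another core.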